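This account rests on a few compounds, and the source may have more. Where it says the series, first, only, none or still open, it means among the compounds named here.

Compound 1 `O=C1ON=C(c2cccs2)/C1=C/c1ccc(F)cc1`: 4800 nM
Compound 2 `O=C1ON=C(c2cccs2)/C1=C/c1ccc(Cl)cc1`: 6200 nM

Both compounds were tested in a functional assay on the whole organism for inhibition, with Rattus norvegicus as the target; on this read-out higher numbers stand for weaker inhibition and lower numbers for stronger inhibition. Compound 2, which carries a chloro group, gives 6200 nM, and this cannot be told apart from compound 1 at 4800 nM. For the measured compounds named here, the only measured step is a 1.3-fold higher number from compound 1 to compound 2 (0.11 log units; within the scatter), where chloro takes the place of fluoro. On these numbers, compound 2 stands level with compound 1.

The next compound, compound 3 `CC(=O)Oc1ccc(/C=C2\C(=O)ON=C2c2cccs2)cc1`, keeps the shared core and changes one group: acetoxy in place of chloro on an aromatic carbon, para to a large group (acetoxy in place of chloro on an aromatic carbon). The measured step bears on this change only weakly. Going by the values given here, it compares chloro with fluoro and shows only that these two groups give numbers within the scatter. Among the compounds with values here, no measured compound carries an acetoxy group, so the data point to no direction. The best guess is therefore no step beyond the scatter, held with wide uncertainty.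

The expected step is a 1.0-fold lower number from compound 2 to compound 3 (0.01 log units; within the scatter). Compound 3 is estimated at 6000 nM, with an expected range from 2000 nM to 18000 nM.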

Compound 3, half-maximal inhibitory concentration: 4500 nM
Beside the measured number, compound 3's estimate is 1.3-fold (0.12 log units) above it; the measured number falls inside the stated range.
By their numbers in this assay, from the lowest: compounds 3, 1 and 2 (each within the scatter of the next).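

In this assay, this place on the aromatic carbon, para to a large group, now holds a group of a different kind. Acetoxy brings four heavy atoms, a double bond outside aromatic rings and two hydrogen-bond acceptors where chloro brings one heavy atom and no acceptor, yet the result is a 1.4-fold lower number from compound 2 to compound 3 (0.14 log units; within the scatter), and the comparison with the fluoro compound gives a 1.1-fold lower number from compound 1 to compound 3 (0.03 log units; within the scatter). For the compounds shown here, the earlier chloro and fluoro pair could show only that two halogens give numbers within the scatter, whereas these steps show that a clearly larger group carrying acceptors also stays within it, and nothing available explains why the number holds so steady across these groups.

On these data alone, it remains open whether this tolerance extends to an amine, a carboxylic acid or a longer chain at the same place, since three compounds cover only a small part of what could sit there. As far as these compounds go, it is also open whether a change elsewhere on the shared core would matter as little as these changes do.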